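The source may hold more compounds than are shown below. What is called first, only, known or untested is meant among the compounds shown, and "the series" means these compounds.

Measured compounds in a functional assay on M14 cells (Homo sapiens) for cytotoxicity, read by sulforhodamine B assay, with a stated time of 48 h; a higher number here means that more compound is tolerated, a lower number that less compound is tolerated:
compound 1 `ClCc1ccc(Cn2cnc3c(Cl)ncnc32)cc1`: 9120 nM
compound 2 `Nc1nc(Cl)c2ncn(Cc3ccc(CCl)cc3)c2n1`: > 100000 nM, which is a limit of the assay and not a number
compound 3 `ClCc1ccccc1Cn1cnc2c(Cl)ncnc21`: 7240 nM

Compound 1 and compound 2 share a core and differ in one place: amino in place of hydrogen on an aromatic carbon. In this assay this change gives an at least 10-fold higher number from compound 1 to compound 2 (1.04 log units; beyond the scatter). The value of compound 2 is a limit of the assay (the limit of > 100000 nM in this assay, at which 1 of the 3 values shown sits). Compound 3 has the same atoms as compound 1 joined differently; the difference between the two cores is not broken down here. In this assay the values of compound 1 and compound 3 sit within the usual scatter of each other, so no order between them is claimed.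

Compound 4 `Nc1nc(Cl)c2ncn(Cc3ccccc3CCl)c2n1` has not been measured. It stands to compound 3 as compound 2 stands to compound 1: amino in place of hydrogen on an aromatic carbon. The surroundings of the place are described in the same words for both pairs, so this is the same change made on the other core.

For compound 4 in this assay a step of about the same size is expected, an 11-fold higher number from compound 3 to compound 4 (1.04 log units; beyond the scatter). This expectation rests on the measured step of an at least 10-fold higher number from compound 1 to compound 2 (1.04 log units; beyond the scatter), and on compound 3 starting from 7240 nM, close to where compound 1 starts with 9120 nM. Compound 4 is therefore estimated at about 80000 nM in this assay, within 30000 nM to 300000 nM, with a real chance that the assay again returns only a limit.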

Compound 4, concentration lethal to 50% of the cells: > 100000 nM
Compound 4: a limit, no number; the forecaster's own chance of this, stated with the estimate: 50%; middle value at least 1.2-fold (0.09 log units) away from the limit.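

In this assay, amino in place of hydrogen on an aromatic carbon gives an at least 13-fold higher number from compound 3 to compound 4 (1.14 log units; beyond the scatter), so the direction and the large size seen on the core of compound 1 recur on the core of compound 3: the same change on two cores in this assay, an at least 10-fold higher number (1.04 log units; beyond the scatter) from compound 1 to compound 2 and an at least 13-fold higher number (1.14 log units; beyond the scatter) from compound 3 to compound 4; the limit leaves it open whether they differ

Compound 2 and compound 4 both end at a limit of the assay and not at a number: the limit of > 100000 nM in this assay, at which 2 of the 4 values shown sit.

The series therefore shows that, on these two cores, the change carries over at least as a large step towards more compound being tolerated, but it does not give the true size of either step and supports no rule for cores beyond these two.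

The compounds shown leave open whether this step belongs to amino itself or would also appear with another group at the same place, such as a methylamino group, a dimethylamino group, a hydroxyl group or a methyl group. They also leave open whether the step would persist if the chloro group on the same ring, or the chloromethyl group on the benzene ring, gave way to another group, such as a methoxy group or a longer chain.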